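The source may hold more compounds than are shown below. What is called first, only, known or untested is meant among the compounds shown, and "the series" means these compounds.

Measured compounds:
compound 1, `Fc1cc(-c2ccccn2)cc(-n2nnc(-c3ccccn3)n2)c1`, 39 nM
compound 2, `Cc1cccnc1-c1cc(F)cc(-n2nnc(-c3ccccn3)n2)c1`, 31 nM

In a functional assay for antagonist activity at metabotropic glutamate receptor 5 (Rattus norvegicus) (a lower number here means a stronger inhibitor, a higher number a weaker inhibitor), compound 2 holds the lowest of the two numbers, and its nearest neighbour is compound 1 at a 1.3-fold lower number from compound 1 to compound 2 (0.10 log units; within the scatter). Compound 3, `Cc1ccncc1-c1cc(F)cc(-n2nnc(-c3ccccn3)n2)c1`, differs from compound 2 by 4-methylpyridin-3-yl in place of 3-methylpyridin-2-yl on an aromatic carbon. Going by the values given here, the only measured step, a 1.3-fold lower number from compound 1 to compound 2 (0.10 log units; within the scatter), concerns adding a methyl, not moving the ring nitrogen, so it gives no direct guide. Compound 3 is therefore estimated at 120 nM (range 30 nM to 500 nM), an expected 3.9-fold higher number from compound 2 to compound 3 (0.59 log units; beyond the scatter) with wide uncertainty.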

Compound 3, half-maximal inhibitory concentration: 5 nM
Compound 3: middle estimate off by 24-fold (1.38 log units), on the high side; measured number outside the range, below it.
By their numbers in this assay, from the lowest: compound 3; then compounds 2 and 1 (each within the scatter of the next).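

In this assay, putting 4-methylpyridin-3-yl in place of 3-methylpyridin-2-yl gives a 6.2-fold lower number from compound 2 to compound 3 (0.79 log units; beyond the scatter) and shows that this position responds to how the same atoms are arranged, which the earlier methyl step, within the scatter, could not show. In place of pyridin-2-yl, the same group gives a 7.8-fold lower number from compound 1 to compound 3 (0.89 log units; beyond the scatter) and thus also stands clear of the scatter. Nothing measured here accounts for this gain.

Both the ring nitrogen and the methyl shift in this change, and the compounds shown leave open which of them carries the step. On these data alone, whether a methoxy group or an amine could take the place of that methyl also remains open.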